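Azido replaces diisopropylamino in an unmeasured compound

The source may hold more compounds than are shown below. What is called first, only, known or untested is meant among the compounds shown, and "the series" means these compounds.

In a functional assay on SW480 cells (Homo sapiens) for antiproliferative activity, read by MTT assay, with a stated time of 48 h (on this read-out higher numbers stand for weaker inhibition and lower numbers for stronger inhibition), compound 1 `CC(=O)O[C@]1(C)/C=C/C(=O)/C(CO)=C\C[C@](C)(CCC=C(C)C)/C=C/[C@H]1OC(=O)C=C(C)C` gives 2010 nM as its half-maximal inhibitory concentration. Compound 2 `CC(C)=CCC[C@]1(C)/C=C/[C@@H](OC(=O)C=C(C)C)[C@](C)(O)/C=C/C(=O)/C(CN(C(C)C)C(C)C)=C\C1` gives 750 nM and so holds the lower of the two numbers, with a gap to compound 1 that lies beyond the usual scatter of repeated measurements. Compound 3 `CC(C)=CCC[C@]1(C)/C=C/[C@@H](OC(=O)C=C(C)C)[C@](C)(O)/C=C/C(=O)/C(CN=[N+]=[N-])=C\C1` has not yet been measured. It differs from compound 2 in one place, through the change azido in place of diisopropylamino on a saturated chain carbon bound to a double-bonded ring carbon on a saturated chain carbon bound to a double-bonded ring carbon. Within the data shown here, no measured pair differing in one place is available as a guide, so any expectation in this assay is loose. Compound 1 at 2010 nM is the only other measured point, and it suggests a modest move toward weaker inhibition. The expected step is a 2.0-fold higher number from compound 2 to compound 3 (0.30 log units; within the scatter) in that direction. For compound 3 the estimated value is 1500 nM with a range from 500 nM to 4500 nM around it.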

Compound 3, half-maximal inhibitory concentration: 4230 nM
For compound 3 the middle estimate is 2.8-fold (0.45 log units) below the measured one; measured number inside the range.
By their numbers in this assay, from the lowest: compound 2; then compound 1; then compound 3.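

In this assay, the change from diisopropylamino to azido on a saturated chain carbon bound to a double-bonded ring carbon gives a 5.6-fold higher number from compound 2 to compound 3 (0.75 log units; beyond the scatter), with the rest of the structure unchanged. Among these compounds, this is the first direct evidence that the group at this position matters to the read-out, and here azido goes with weaker inhibition than diisopropylamino. Nothing in the data explains this shift.

A single pair cannot show whether the loss of diisopropylamino or the arrival of azido drives the difference. A different amine at this position, such as dimethylamino or morpholine, would help separate the two, and a carboxylic acid there would test a group of another kind.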